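This account rests on a few compounds, and the source may have more. Where it says the series, first, only, none or still open, it means among the compounds named here.

Three compounds have so far been measured in a functional assay on THP-1 cells (Homo sapiens) for inhibition, read by sulforhodamine B assay, with a stated time of 48 h, tested at 50 uM; a higher number here means more inhibition of growth at the concentration tested, a lower number less inhibition of growth:

Compound 1, `O=C1C(=O)N(CCCCn2cc(COc3cc(=O)oc4ccccc34)nn2)c2ccc(F)cc21`, gives 77%.
Compound 2, `O=C1C(=O)N(CCCn2cc(COc3cc(=O)oc4ccccc34)nn2)c2ccc(F)cc21`, gives 86%.
Compound 3, `COc1ccc2c(c1)C(=O)C(=O)N2CCCCCn1cc(COc2cc(=O)oc3ccccc23)nn1`, gives 30%.

Compound 1 stands second highest of these three numbers. Its closest neighbour is compound 2, whose number is somewhat higher, but the gap between the two lies within the usual scatter of such measurements, so the two cannot be told apart. Compound 3 lies far lower, and that gap is well beyond the scatter.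

The next compound, compound 4, `O=C1C(=O)N(CCCCn2cc(COc3cc(=O)oc4ccccc34)nn2)c2ccc(Cl)cc21`, differs from compound 1 in a single spot: chloro in place of fluoro on an aromatic carbon. Everything else in the two molecules is the same.

Among the compounds with values here, no pair of measured compounds differs from each other in this way, so there is no measured step to lean on. A swap of one halogen for another at the same aromatic carbon is a small change in the molecule, and the expectation is a step of a number 1 percentage points lower from compound 1 to compound 4 (within the scatter), that is, no change beyond the scatter. On that basis compound 4 is estimated to give 76% in this assay, with a likely range from 58% to 90%.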

Compound 4, percent growth inhibition at one concentration: 71%
Compound 4: middle estimate off by 5 percentage points, on the high side, within the range that was stated.
By their numbers in this assay, from the lowest: compound 3; then compounds 4, 1 and 2 (each within the scatter of the next, the first and the last beyond it).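

In this assay, within the data shown here, putting chloro in place of fluoro on this aromatic carbon gives a number 6 percentage points lower from compound 1 to compound 4 (within the scatter), and this is the first measured step at this position. With the chain that links the two halves of compound 1, and at the single concentration tested, the two halogens therefore cannot be told apart at this carbon, although a real difference smaller than the scatter cannot be excluded. Nothing measured alongside these numbers bears on why the swap leaves the growth inhibition at this level.

Still open, going by these compounds, is whether a group of another kind on this carbon, such as an amine, a nitrile or a carboxylic acid, or a plain hydrogen, would move the number beyond the scatter, since two halogens alone say little about the wider range of groups possible here. Also open, on these data alone, is whether the same swap would give an equally small step on the chain of compound 2, and what lies behind the low number of compound 3, which differs from the others in more than one place.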